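From methoxy to benzyloxycarbonyl on a shared core

The source may hold more compounds than are shown below. What is called first, only, known or untested is meant among the compounds shown, and "the series" means these compounds.

Measured so far in a functional assay on MCF7 cells (Homo sapiens) for antiproliferative activity, read by MTT assay, with a stated time of 48 h (a higher number here means a weaker inhibitor, a lower number a stronger inhibitor), are these compounds
compound 1 `O=C(OCc1ccccc1)c1ccc2[nH]c(-c3cn(-c4ccccc4)nc3-c3ccccc3)nc2c1` gives 12600 nM
compound 2 `COc1ccc(-c2nn(-c3ccccc3)cc2-c2nc3cc(Br)ccc3[nH]2)cc1` gives 1830 nM
compound 3 `COc1ccc(-c2nn(-c3ccccc3)cc2-c2nc3cc(OC)ccc3[nH]2)cc1` gives 3130 nM

Compound 3 lies within the scatter of compound 2, and its number is clearly lower than that of compound 1. Compound 4 `COc1ccc(-c2nn(-c3ccccc3)cc2-c2nc3cc(C(=O)OCc4ccccc4)ccc3[nH]2)cc1` carries benzyloxycarbonyl in place of methoxy on an aromatic carbon of compound 3 (benzyloxycarbonyl in place of methoxy on an aromatic carbon). Going by the values given here, the one measured step is a 1.7-fold higher number from compound 2 to compound 3 (0.23 log units; within the scatter) with methoxy in place of bromo, and it involves no benzyloxycarbonyl. Compound 1 does carry that group and gives 12600 nM in this assay with a number higher than that of compound 3, though its core differs elsewhere. A rise is therefore expected, and the estimate is a 1.9-fold higher number from compound 3 to compound 4 (0.28 log units; within the scatter) for this change. For compound 4 the expected value is 6000 nM and it is estimated to fall from 2200 nM to 16000 nM when measured.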

Compound 4, half-maximal inhibitory concentration: 7460 nM
Compound 4: the middle estimate sits 1.2-fold (0.09 log units) below what was measured, and the stated range covers the measured number.
By their numbers in this assay, from the lowest: compounds 2 and 3 (each within the scatter of the next); then compounds 4 and 1 (each within the scatter of the next).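

In this assay, benzyloxycarbonyl on this aromatic carbon separates from the smaller groups, where methoxy and bromo did not separate from each other: the change gives a 2.4-fold higher number from compound 3 to compound 4 (0.38 log units; beyond the scatter) and a 4.1-fold higher number from compound 2 to compound 4 (0.61 log units; beyond the scatter) in turn. With benzyloxycarbonyl on both compounds, methoxy in place of hydrogen on the other aromatic ring gives a 1.7-fold lower number from compound 1 to compound 4 (0.23 log units; within the scatter) and so does not separate them. Nothing measured here explains these steps. On these data alone, whether an amine or a carboxylic acid on this carbon would track benzyloxycarbonyl or the smaller groups remains open.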